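Methyl on the chain: compound 1 to compound 4

A few compounds are considered here, and "the series" means these few. Any claim that something is new, unique, unknown or untested is made for them only; others in the source may bear on it.

Working notes on a small set of amides sharing one core. Among the compounds with values here, compound 1 `O=C(CCSc1nnc(-c2ccncc2)s1)Nc1ccc(Cl)cc1` is the only member with a numerical reading in an ADME assay on BHK-21 cells (Mesocricetus auratus) for cytotoxicity, with a stated time of 3 days (on this read-out higher numbers stand for lower toxicity in this test and lower numbers for higher toxicity in this test), where compound 1 gives 8210 nM. Compound 2 `O=C(CSc1nnc(-c2ccncc2)s1)Nc1ccc(Cl)cc1` reaches only a limit of this assay, returning > 50000 nM. Compound 3 `CC(Sc1nnc(-c2ccncc2)s1)C(=O)Nc1ccc(Cl)cc1Cl` likewise stops at a limit in this assay, with > 50000 nM. Within the data shown here, two of the three readings therefore rest at the limit of > 50000 nM in this assay, at which 2 of the 3 values shown sit, and no measured pair differs in a single place, so no measured step is available to lean on. The unmeasured compound 4 `CC(CSc1nnc(-c2ccncc2)s1)C(=O)Nc1ccc(Cl)cc1` differs from compound 1 by methyl in place of hydrogen on a saturated chain carbon bound to a carbonyl carbon and a saturated chain carbon. Among the measured compounds shown here, with no comparable measured step in hand, the expected step in this assay is a 1.8-fold higher number from compound 1 to compound 4 (0.26 log units; within the scatter), in the direction of lower toxicity and not far beyond the usual scatter. Compound 4 is accordingly estimated at 15000 nM, in the range 5000 nM to 50000 nM, with a real chance that only a limit is returned.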

Compound 4, half-maximal cytotoxic concentration: > 50000 nM
Compound 4 ended at the assay's limit; the forecaster's own chance of this, stated with the estimate: 35%; middle value at least 3.3-fold (0.52 log units) from the limit.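

Methyl in place of hydrogen on a saturated chain carbon bound to a carbonyl carbon and a saturated chain carbon provides the only step in the series between compounds that differ in one place: in this assay the change gives an at least 6.0-fold higher number from compound 1 to compound 4 (0.78 log units; beyond the scatter), in the direction of lower toxicity in this test. Within the data shown here, this single added carbon is enough to move the reading from the only numerical value in the set to the limit of the assay. The step is only a lower bound on the true size, because compound 4 reaches a limit and not a number: the limit of > 50000 nM in this assay, at which 3 of the 4 values shown sit.

From the compounds shown here alone, how far compound 4 lies past that limit remains open. Also open, going by these compounds, is whether the change is specific to methyl, or whether ethyl, hydroxyl or an amine on the same chain carbon would give a similar reading.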